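The compounds below may be only part of what the source reports. "The series", "measured", "known", "first", "only" and "open" are said of these compounds alone.

Two uracil nucleotides have been measured in an in vitro functional assay on 1321-N1 cells for agonist activity at P2Y purinoceptor 6 (Homo sapiens), read by calcium flux; on this read-out lower numbers stand for an effect already at smaller amounts and higher numbers for an effect only at larger amounts of compound. Compound 1 `O=c1ccn([C@]23C[C@H]2[C@H](COP(=O)(O)OP(=O)(O)O)[C@@H](O)[C@H]3O)c(=O)[nH]1` gives 230 nM in this assay. Compound 2 `O=c1[nH]c(=O)n([C@@H]2O[C@H](COP(=O)(O)OP(=O)(O)OP(=O)(O)O)[C@@H](O)[C@H]2O)cc1Br` gives 800 nM in this assay, the higher of the two numbers; its neighbour is compound 1, and the gap between them lies beyond the scatter of repeated measurements.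

From compound 2 the account moves to compound 3 `O=c1[nH]c(=O)n([C@@H]2O[C@H](COP(=O)(O)OP(=O)(O)S)[C@@H](O)[C@H]2O)cc1Br`, which is not yet measured. The change is one sulfur atom in place of a group of 5 heavy atoms (4 oxygen, 1 phosphorus; no ring), on a phosphorus. Going by the values given here, no measured pair shows this step, so its size is a matter of expectation. Compound 3 is expected to give a lower number than compound 2 in this assay, a step of a 6.7-fold lower number from compound 2 to compound 3 (0.82 log units; beyond the scatter), since compound 1, which also lacks a third phosphorus, gives 230 nM. Compound 3 is estimated at 120 nM, with a range from 30 nM to 500 nM.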

Compound 3, half-maximal effective concentration: 47 nM
Beside the measured number, compound 3's estimate is 2.6-fold (0.41 log units) above it, and the stated range covers the measured number.
By their numbers in this assay, from the lowest: compound 3; then compound 1; then compound 2.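

In this assay, going by these compounds alone, putting a sulfanyl on this phosphorus, whose other neighbours are oxygen, oxygen, in place of the group of 5 heavy atoms (4 oxygen, 1 phosphorus) gives a 17-fold lower number from compound 2 to compound 3 (1.23 log units; beyond the scatter), a large change and the first step between measured compounds that differ in one place. It shows that this group of 5 heavy atoms is not required for an effect here: a single sulfur atom in its place leaves the number lower, not higher. Nothing available here explains why the exchange moves the number in this direction or by this much.

From the compounds shown here alone, how an amine or a methyl group on this phosphorus would compare with the sulfanyl remains open. Also open, going by these compounds, is whether the same exchange would bring a step of similar size on a core without the bromine.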